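Proline amides of p300: an oxindole in place of azaindazole

A few compounds are considered here, and "the series" means these few. Any claim that something is new, unique, unknown or untested is made for them only; others in the source may bear on it.

Measured compounds:
compound 1, `COc1ccc(NC(=O)[C@H]2CCCN2C(=O)C2(c3ccc(Cl)cc3)CCCC2)cc1`, 7.94 nM
compound 2, `O=C(Nc1cnc2[nH]ncc2c1)[C@H]1CCCN1C(=O)C1(c2cccc(Cl)c2)CCCC1`, 15.9 nM
compound 3, `COc1ccc(NC(=O)[C@H]2CCCN2C(=O)C(C)(C)c2ccc(Cl)cc2)cc1`, 50.1 nM

In an assay on isolated protein for inhibition of histone acetyltransferase p300 (Homo sapiens), with a stated time of 60 min (on this read-out higher numbers stand for weaker inhibition and lower numbers for stronger inhibition), compound 2 gives 15.9 nM, the second highest of the three numbers. Its nearest neighbour is compound 1, which in this assay gives 7.94 nM, a gap that lies within the usual scatter, so nothing can be said about which of the two is the stronger inhibitor. The furthest is compound 3, which in this assay gives 50.1 nM, a gap beyond the scatter; compound 3 therefore shows weaker inhibition than compound 2.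

Compound 4, `O=C1Cc2cc(NC(=O)[C@H]3CCCN3C(=O)C3(c4cccc(Cl)c4)CCCC3)ccc2N1`, has not been measured. It differs from compound 2 in one place: a group of 10 heavy atoms (8 carbon, 1 nitrogen, 1 oxygen; one five-membered non-aromatic ring with 1 hetero atom, one six-membered aromatic ring of carbon only) in place of a group of 9 heavy atoms (6 carbon, 3 nitrogen; one five-membered aromatic ring with 2 hetero atoms, one six-membered aromatic ring with 1 hetero atom), on an amide-type nitrogen. Both compounds 1 and 2 carry an aromatic ring on that amide-type nitrogen and sit within the scatter of each other, so the expectation is that the change from compound 2 to compound 4 brings no step beyond the scatter, with at most a small move toward stronger inhibition, as the step of a 1.3-fold lower number from compound 2 to compound 4 (0.12 log units; within the scatter) expresses. Compound 4 is accordingly estimated at 12 nM in this assay, with an expected range from 4 nM to 40 nM.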

Compound 4, half-maximal inhibitory concentration: 0.794 nM
For compound 4 the middle estimate is 15-fold (1.18 log units) above the measured one; measured number below the stated range.
By their numbers in this assay, from the lowest: compound 4; then compounds 1 and 2 (each within the scatter of the next); then compound 3.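

In this assay, putting the group with one five-membered non-aromatic ring with 1 hetero atom and one six-membered aromatic ring of carbon only on the amide-type nitrogen, in place of the group with one five-membered aromatic ring with 2 hetero atoms and one six-membered aromatic ring with 1 hetero atom, gives a 20-fold lower number from compound 2 to compound 4 (1.30 log units; beyond the scatter). Within the data shown here, this is the first comparison that isolates this position, since compounds 1, 2 and 3 differ from one another in more than one place, and it shows that the read-out depends strongly on the group carried there, even though the two groups differ by a single heavy atom and both have 1 hydrogen-bond donor, while the acceptor count goes from 2 to 1. No measurement available here accounts for the size of this step.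

The compounds shown leave open which feature of the entering group matters, which a methyl group on its ring nitrogen or an indole in its place could help to separate. They also leave open whether the same exchange would give a step of similar size on the core of compound 1 or of compound 3.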